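The source may report more compounds than this note shows. Statements on the series, on what has been measured and on what is new or still open speak of the compounds shown alone.

The measured compounds and their values in a functional assay for inhibition, tested at 100 uM; a lower number here means less inhibition, a higher number more inhibition at the concentration tested (going by the name of the read-out):
compound 1, `O=S(=O)(CC1=NCCS1)c1c[nH]cc1S(=O)(=O)c1ccc(Cl)cc1`, 41.4%
compound 2, `O=S(=O)(/C=C/S(=O)(=O)c1ccc(Cl)cc1)CC1=NCCS1`, 32.3%
compound 3, `O=S(=O)(/C=C/S(=O)(=O)c1ccccc1)CC1=NCCS1`, 30.4%

Of the compounds shown here, three have been measured in this assay. Compound 2 and compound 3 differ in one place: hydrogen in place of chloro on an aromatic carbon. This change gave a number 1.9 percentage points lower from compound 2 to compound 3 (within the scatter), so within this pair the chloro substituent made no difference that the assay can resolve. Compound 1 differs from compound 2 in more than one place; how the two cores differ is not broken down here. Compound 1 gave a number within the scatter of compound 2, and a number beyond the scatter above compound 3.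

Compound 4, `O=S(=O)(CC1=NCCS1)c1c[nH]cc1S(=O)(=O)c1ccccc1`, is not yet measured. It stands to compound 1 as compound 3 stands to compound 2: hydrogen in place of chloro on an aromatic carbon. The two changes are the same, made at the same kind of place on the same kind of ring. On the core of compound 1 this change is expected to give a step of about the same size, a number 2.4 percentage points lower from compound 1 to compound 4 (within the scatter), because the earlier step of a number 1.9 percentage points lower from compound 2 to compound 3 (within the scatter) on the other core was within the scatter. The estimate for compound 4 in this assay is therefore 39%, with a likely range from 26% to 52%. That this rests on a single pair leaves the expectation open to error.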

Compound 4, a percentage reported as inhibition, at one concentration (the size of the read-out at that concentration, not a potency): 34.6%
The estimate for compound 4 lay 4.4 percentage points above the measured number; low and high end bracket the measured number.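

In this assay, hydrogen in place of chloro gave a number 6.8 percentage points lower from compound 1 to compound 4 (within the scatter), so on this core too the chloro substituent made no difference that the assay can resolve. Set beside the earlier step, the change carried from one core to the other with no difference that can be told apart: the same change on two cores in this assay, a number 1.9 percentage points lower (within the scatter) from compound 2 to compound 3 and a number 6.8 percentage points lower (within the scatter) from compound 1 to compound 4, 4.9 percentage points apart, within the scatter of two such steps. This shows only that the 4-chlorophenyl to phenyl change stayed within the scatter on these two cores; it does not show that the two steps are equal, and two pairs cannot say how the change would behave on any further core.

The compounds shown leave open what a group other than chloro or hydrogen would do at this place on the six-membered aromatic ring, for example a methoxy group, an amine or a carboxylic acid. They also leave open what an amide in place of either sulfonyl group would do.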